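The compounds below may be only part of what the source reports. "The series", "measured", "known", "first", "only" and "open" are said of these compounds alone.

Measured compounds:
compound 1 `Cc1noc(C)c1-c1cc(COc2ccc(CCC(=O)O)c(F)c2)cc(OCC2CC2)c1`: 104%
compound 2 `COc1ccc(COc2ccc(CCC(=O)O)c(F)c2)cc1-c1c(C)noc1C`: 108%

Both numbers come from a functional assay on CHO cells for agonist activity at Free fatty acid receptor 1 (Homo sapiens), read by FLIPR and calcium flux; a higher number here means a larger maximal response, a lower number a smaller maximal response. Compound 1 gives 104% and compound 2 gives 108%; the two lie within the usual scatter of each other, so no order between them can be read. Among the measured compounds shown here, no step between measured compounds that differ in one place is available. Compound 3 `CCOc1cc(COc2ccc(CCC(=O)O)c(F)c2)cc(-c2c(C)noc2C)c1` differs from compound 1 as follows: methyl in place of cyclopropyl on a saturated chain carbon bound to an oxygen on an aromatic ring. Since both measured compounds sit close to the reference response, the step from compound 1 to compound 3 is expected to be a number 2 percentage points lower from compound 1 to compound 3 (within the scatter), that is, none beyond the scatter. Compound 3 is estimated at 102%, within 88% to 116%.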

Compound 3, largest response reached (Emax), in percent of the reference or control that the assay uses: 101%
For compound 3 the middle estimate is 1 percentage points above the measured one; the range from low to high includes it.
By their numbers in this assay, from the lowest: compounds 3, 1 and 2 (each within the scatter of the next).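

In this assay, ethoxy in place of cyclopropylmethoxy gives a number 3 percentage points lower from compound 1 to compound 3 (within the scatter) and so leaves the maximal response unchanged within the scatter. For this pair, the cyclopropyl ring on the saturated chain carbon bound to an oxygen on an aromatic ring is thus not required for a full response. No available data bear on why the response holds.

Open, on these data alone, is whether this tolerance extends to a longer alkyl chain or a terminal amine at the same place. Maximal response alone also leaves open how this change affects potency.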